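From Methoxy to Ethoxy on the Aryl Group

The source may hold more compounds than are shown below. What is called first, only, known or untested is meant among the compounds shown, and "the series" means these compounds.

Compound 1 `COc1cc(C(=O)c2sc(-c3ccc(F)cc3)cc2N)cc(OC)c1OC` gives 20 nM
Compound 2 `COc1ccc(-c2cc(N)c(C(=O)c3cc(OC)c(OC)c(OC)c3)s2)cc1` gives 45 nM

Going by the values given here, in a functional assay on L1210 cells (Mus musculus) for antiproliferative activity (a lower number here means a stronger inhibitor, a higher number a weaker inhibitor), compound 2 holds the higher of the two numbers, at 45 nM, and compound 1 is its only measured neighbour. Separating them is a 2.3-fold higher number from compound 1 to compound 2 (0.35 log units; beyond the scatter), a modest step that comes with methoxy in place of fluoro on an aromatic carbon.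

Compound 3 `CCOc1ccc(-c2cc(N)c(C(=O)c3cc(OC)c(OC)c(OC)c3)s2)cc1` differs from compound 2 by methyl in place of hydrogen on a saturated chain carbon bound to an oxygen on an aromatic ring. In other words, methoxy becomes ethoxy, and 4-methoxyphenyl becomes 4-ethoxyphenyl. Among the compounds with values here, no measured step shows this exact change. The step from fluoro to methoxy is the only one that bears on it, as it introduced the methoxy now being extended. A single step establishes no trend, so it serves only as a rough guide to size and direction. A step no larger than that modest one is expected in this assay, leaning slightly towards a higher number. The expected change is a 1.3-fold higher number from compound 2 to compound 3 (0.12 log units; within the scatter). Compound 3 is estimated at 60 nM, with an expected range of 22 nM to 170 nM.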

Compound 3, half-maximal inhibitory concentration: 590 nM
The estimate for compound 3 lay 9.8-fold (0.99 log units) below the measured number, and the stated range ends below it.
By their numbers in this assay, from the lowest: compound 1; then compound 2; then compound 3.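

In this assay the added methyl on the saturated chain carbon bound to an oxygen on an aromatic ring brings a 13-fold higher number from compound 2 to compound 3 (1.12 log units; beyond the scatter) and so turns methoxy into ethoxy at a large cost, whereas the earlier change from fluoro to methoxy at this aromatic carbon was only modest. Taken directly from the fluoro compound, the change to ethoxy gives a 30-fold higher number from compound 1 to compound 3 (1.47 log units; beyond the scatter) and shows that among these three compounds the number rises with each replacement, with the second step far larger than the first. Nothing available accounts for this sharp rise on the addition of a single carbon.

From the compounds shown here alone, whether the rise is particular to ethoxy or continues with a longer chain such as propoxy stays open, as does whether a branched isopropoxy or a hydroxyl or amine at this aromatic carbon would fall nearer to compound 1 and compound 2. All three compounds share the rest of their structure, so they cannot tell whether methoxy to ethoxy would weigh as heavily on a different core.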